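The source may report more compounds than this note shows. Statements on the series, on what has been measured and on what is new or still open speak of the compounds shown alone.

Compound 1 `Cn1cc(-c2cnc3ccc(NCc4ccc(F)cc4)nc3c2)cn1` carries a fluoro group on its outer aromatic ring. In a functional assay on A549 cells (Homo sapiens) for antiproliferative activity, read by MTT assay, with a stated time of 48 h (a lower number here means a stronger inhibitor, a higher number a weaker inhibitor), compound 1 reaches only a limit of the assay, > 50000 nM. Compound 2 `COc1ccc(CNc2ccc3ncc(-c4cnn(C)c4)cc3n2)cc1` is obtained from it by one change, (methoxy in place of fluoro on an aromatic carbon). In this assay compound 2 likewise stops at a limit, > 50000 nM. The step that the two limits leave unreadable from compound 1 to compound 2 therefore cannot be read, because both values sit at the limit of > 50000 nM in this assay, at which 3 of the 3 values shown sit.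

Compound 3 `Cn1cc(-c2cnc3ccnc(NC(=O)c4ccc(F)cc4)c3c2)cn1` has a different core; the difference between its core and the core of compound 1 is not broken down here. In this assay compound 3 also gives only a limit, > 50000 nM.

Compound 4 `COc1ccc(C(=O)Nc2nccc3ncc(-c4cnn(C)c4)cc23)cc1` has not yet been measured. It differs from compound 3 by methoxy in place of fluoro on an aromatic carbon. The place of this change is described in the same words as for the change from compound 1 to compound 2, so it is the same change, made a second time on a different core.

Since the earlier change did not move its pair off the limit, nothing here suggests that the second one will. The step that the limit leaves unreadable from compound 3 to compound 4 is expected to be just as small and unreadable, an expectation that rests on compound 3 sitting at the limit of > 50000 nM in this assay, at which 3 of the 3 values shown sit. Compound 4 is accordingly estimated at 70000 nM, with a range from 20000 nM to 300000 nM, most probably reported again only as a limit.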

Compound 4, half-maximal inhibitory concentration: > 50000 nM
Compound 4 ended at the assay's limit; the forecaster's own chance of this, stated with the estimate: 85%; the middle value does not contradict the limit.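

The step from compound 3 to compound 4 cannot be read, because both compounds stop at a limit of the assay and give no actual number: the limit of > 50000 nM in this assay, at which 4 of the 4 values shown sit. The compounds shown leave open whether 4-fluorophenyl and 4-methoxyphenyl differ at all in this assay on either core, and which structure, if any, would give a measured value there.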